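A few compounds are considered here, and "the series" means these few. Any claim that something is new, unique, unknown or untested is made for them only; others in the source may bear on it.

Working notes on the series.

Compound 3 `COc1ccc(C2CC(c3ccc(Cl)cc3)=NN2c2ccc(-c3ccccc3)nn2)c(OC)c1` stands on a limit only: in a functional assay on A549 cells (Homo sapiens) for antiproliferative activity, read by MTT assay, with a stated time of 24 h (on this read-out higher numbers stand for weaker inhibition and lower numbers for stronger inhibition), compound 3 gives > 100000 nM, a limit of the assay rather than a number. Compound 2 `Clc1ccc(C2=NN(c3ccc(-c4ccccc4)nn3)C(c3ccc(Cl)cc3)C2)cc1` likewise sits on a limit, giving > 100000 nM in this assay. Going by the values given here, compound 1 `COc1cc(C2CC(c3ccccc3)=NN2c2ccc(-c3ccccc3)nn2)cc(OC)c1OC` is the one member with a measured number, giving 83800 nM in this assay. Among the compounds with values here, the one step that joins two measured compounds, a step that the two limits leave unreadable from compound 2 to compound 3, cannot be sized, because the limit of > 100000 nM in this assay, at which 2 of the 3 values shown sit, holds both of its ends.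

Compound 4 `COc1cc(C2CC(c3ccc(Cl)cc3)=NN2c2ccc(-c3ccccc3)nn2)cc(OC)c1OC` differs from compound 3 in one place: 3,4,5-trimethoxyphenyl in place of 2,4-dimethoxyphenyl on a saturated ring carbon. Within the data shown here, no measured step bears directly on this change. Compound 4 shares with compound 1 the 3,4,5-trimethoxyphenyl on the saturated ring carbon and shares with compound 3 the 4-chlorophenyl, and the two values of compound 1 and compound 3 span a measured number and a limit. Compound 4 is therefore expected near the number of compound 1, with a real chance of a limit: the expected value is 90000 nM, between 40000 nM and 200000 nM, so the step of an at least 1.1-fold lower number from compound 3 to compound 4 (0.04 log units; that floor lies within the scatter) is expected to be unreadable or small.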

Compound 4, half-maximal inhibitory concentration: 83300 nM
Compound 4: middle estimate off by 1.1-fold (0.03 log units), on the high side; the measured number falls inside the stated range.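

With the 4-chlorophenyl kept, the 3,4,5-trimethoxyphenyl on the saturated ring carbon gives a measured number in this assay, with an at least 1.2-fold lower number from compound 3 to compound 4 (0.07 log units; that floor lies within the scatter) and an at least 1.2-fold lower number from compound 2 to compound 4 (0.07 log units; that floor lies within the scatter). Both steps are readable only as floors, each with one end on a limit of the assay: the limit of > 100000 nM in this assay, at which 2 of the 4 values shown sit.

Going by these compounds alone, the chloro in place of hydrogen on an aromatic carbon, a change no earlier pair covered, gives a 1.0-fold lower number from compound 1 to compound 4 (0.00 log units; within the scatter), so with the 3,4,5-trimethoxyphenyl present the two compounds stand within the scatter of each other.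

Open, as far as these compounds go, is whether an amine or a carboxylic acid on the aromatic ring at the saturated ring carbon would give a step from compound 4 beyond the scatter in this assay. Also open, from the compounds shown here alone, is what such groups would do elsewhere on the shared core.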